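The source may report more compounds than this note shows. Statements on the series, on what has been measured and on what is new or still open speak of the compounds shown alone.

Compound 2 `COc1cc(OC)c(C(=O)/C=C/c2cccc(N3CCNCC3)c2)c(O)c1C` sits with compound 1 `COc1cc(OC)c(C(=O)/C=C/c2cccc(Cl)c2)c(O)c1CC=C(C)C` and compound 3 `COc1cc(OC)c(C(=O)/C=C/c2cccc(N3CCN(C)CC3)c2)c(O)c1CC=C(C)C` in a short run of chalcones on one shared core. In an ADME assay on MCF7-DOX cells (Homo sapiens) for cytotoxicity, read by MTT assay, with a stated time of 48 h (a higher number here means a weaker inhibitor, a lower number a stronger inhibitor), compound 2 gives 98700 nM. Compound 1 gives 59500 nM in this assay, and the two values lie within the scatter of each other, so no order between them is claimed. For compound 3 this assay reports only a limit, > 100000 nM. Among the compounds with values here, the one single-point step, an at least 1.6-fold higher number from compound 1 to compound 3 (0.22 log units; that floor lies within the scatter), is bounded by the limit of > 100000 nM in this assay, at which 1 of the 3 values shown sits, and carries the 4-methylpiperazin-1-yl in place of chloro; it is not the change at hand. Compound 4 `CCCCc1c(OC)cc(OC)c(C(=O)/C=C/c2cccc(N3CCNCC3)c2)c1O` differs from compound 2 by propyl in place of hydrogen on a saturated chain carbon bound to an aromatic carbon. Compound 1 and compound 2 differ in two places at once, so their values say nothing separable about the chain at that position. Within the data shown here, no measured step bears on this change, and no shift beyond the scatter is expected in this assay. The estimate for compound 4 in this assay is 95000 nM, between 40000 nM and 200000 nM, meaning a step of a 1.0-fold lower number from compound 2 to compound 4 (0.02 log units; within the scatter) that is expected to stay within the scatter.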

Compound 4, half-maximal inhibitory concentration: > 100000 nM
Compound 4 gave a limit, no number; the forecaster's own chance of this, stated with the estimate: 40%; middle value at least 1.0-fold (0.02 log units) from the limit.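

In this assay compound 4 returns only a limit, so the butyl chain has no number of its own at this position. The step, an at least 1.0-fold higher number from compound 2 to compound 4 (0.00 log units; that floor lies within the scatter), gives a floor and no size: it shows only that propyl in place of hydrogen on a saturated chain carbon bound to an aromatic carbon did not bring the number down. The earlier compounds shown here could not give this reading. None of them isolated this change. Readings in this series now gather at one ceiling: the limit of > 100000 nM in this assay, at which 2 of the 4 values shown sit.

From the compounds shown here alone, the true size of the step remains open, including whether this change moves the number at all. Also open, going by these compounds, is whether an ethyl chain, or a chain ending in an amine or a carboxylic acid, at this position on the core of compound 2 would give a value inside the range of this assay.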